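From Trifluoromethyl to Trifluoromethoxy at the Assay Limit

This account rests on a few compounds, and the source may have more. Where it says the series, first, only, none or still open, it means among the compounds named here.

In a functional assay on MCF cells (Homo sapiens) for antiproliferative activity, with a stated time of 72 h (a higher number here means a weaker inhibitor, a lower number a stronger inhibitor), compound 1 (`OC[C@H]1O[C@@H](n2cnc3c(NCc4cccc(F)c4)ncnc32)[C@H](O)[C@@H]1O`), which carries fluoro, gives 15300 nM. Compound 2 (`OC[C@H]1O[C@@H](n2cnc3c(NCc4cccc(Br)c4)ncnc32)[C@H](O)[C@@H]1O`), which carries bromo, gives > 166000 nM, a limit and not a number. Compound 3 (`OC[C@H]1O[C@@H](n2cnc3c(NCc4cccc(C(F)(F)F)c4)ncnc32)[C@H](O)[C@@H]1O`), which carries trifluoromethyl, gives > 166000 nM, also a limit. This is the limit of > 166000 nM in this assay, at which 2 of the 3 values shown sit.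

Compound 4 (`OC[C@H]1O[C@@H](n2cnc3c(NCc4cccc(OC(F)(F)F)c4)ncnc32)[C@H](O)[C@@H]1O`) has trifluoromethoxy in place of trifluoromethyl on an aromatic carbon, meta to a large group: trifluoromethoxy in place of trifluoromethyl on an aromatic carbon. The bearing steps are both large: an at least 10-fold higher number from compound 1 to compound 2 (1.03 log units; beyond the scatter), and an at least 10-fold higher number from compound 1 to compound 3 (1.03 log units; beyond the scatter). The third is a step that the two limits leave unreadable from compound 2 to compound 3. Replacing fluoro gave a large loss in compound 2 and compound 3, so compound 4 is expected to stay near that limit. The expected change is an at least 1.1-fold lower number from compound 3 to compound 4 (0.04 log units; that floor lies within the scatter), with no readable step expected in either direction in this assay. The estimate for compound 4 is 150000 nM, with an expected range of 40000 nM to 350000 nM.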

Compound 4, half-maximal inhibitory concentration: > 166000 nM
Compound 4 ended at the assay's limit; the forecaster's own chance of this, stated with the estimate: 65%; middle value at least 1.1-fold (0.04 log units) away from the limit.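

In this assay, trifluoromethoxy on this aromatic carbon, meta to a large group, joins bromo and trifluoromethyl at the assay's limit, so the steps among these three groups cannot be read. Fluoro remains the only group shown with a readable value, the step away from it is an at least 10-fold higher number from compound 1 to compound 4 (1.03 log units; beyond the scatter) and the added oxygen brings no readable value back. The series now stands mostly at one point: the limit of > 166000 nM in this assay, at which 3 of the 4 values shown sit.

As far as these compounds go, whether hydrogen, methyl, methoxy or an amine here would give a value under the limit stays open. Any order among compound 2, compound 3 and compound 4 also stays open.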